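A Fluoro-Hydroxyphenyl Swap Carried Onto a Weaker Core

The source may hold more compounds than are shown below. What is called first, only, known or untested is meant among the compounds shown, and "the series" means these compounds.

Compound 1 `O=C(NO)c1ccc(/C=C/c2ccnc(-c3cc(F)ccc3O)c2)cc1` and compound 2 `O=C(NO)c1ccc(/C=C/c2ccnc(-c3cccc(O)c3)c2)cc1` share one core, while compound 3 `O=C(NO)c1ccc(/C=C/c2cccc(-c3cccc(O)c3)c2)cc1` and compound 4 `O=C(NO)c1ccc(/C=C/c2cccc(-c3cc(F)ccc3O)c2)cc1` share another, and the difference between the two cores is not broken down here. In a functional assay on HCT-116 cells (Homo sapiens) for antiproliferative activity, read by CellTiter-Glo, with a stated time of 72 h (a lower number here means a stronger inhibitor, a higher number a weaker inhibitor), compound 1 gives 2040 nM and compound 2 gives 1610 nM. The change from compound 2 to compound 1 is 5-fluoro-2-hydroxyphenyl in place of 3-hydroxyphenyl on an aromatic carbon, and it makes a 1.3-fold higher number from compound 2 to compound 1 (0.10 log units; within the scatter). For compound 3 this assay reports only a limit, > 10000 nM, which is the limit of > 10000 nM in this assay, at which 1 of the 3 values shown sits. Compound 4 carries the same kind of change on its own core, (5-fluoro-2-hydroxyphenyl in place of 3-hydroxyphenyl on an aromatic carbon). The surroundings differ: in compound 4 the place is on an aromatic carbon of a six-membered aromatic ring of carbon only, meta to a large group, whereas in compound 1 the ring holds one nitrogen and the place is next to the ring nitrogen, meta to a large group. Because the measured step from compound 2 to compound 1 is a 1.3-fold higher number from compound 2 to compound 1 (0.10 log units; within the scatter), within the scatter, the step expected for compound 4 is a step that the limit leaves unreadable from compound 3 to compound 4. Compound 4 is therefore estimated at 15000 nM, between 7000 nM and 40000 nM, and this assay will most likely again report only a limit for it.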

Compound 4, half-maximal inhibitory concentration: > 10000 nM
Compound 4 gave a limit, no number (the forecaster's own chance of this, stated with the estimate: 75%); the middle value does not contradict the limit.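

In this assay, compound 3 and compound 4 each give only a limit, and no step between them can be read: the limit of > 10000 nM in this assay, at which 2 of the 4 values shown sit.

The compounds shown leave open whether 5-fluoro-2-hydroxyphenyl in place of 3-hydroxyphenyl changes activity at all on the core shared by compound 3 and compound 4.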